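The source may report more compounds than this note shows. Statements on the series, on what has been measured and on what is new or still open speak of the compounds shown alone.

Going by the values given here, compound 1 `Cc1cc(C)c(S(=O)(=O)N2CCC(N3CCC(CCO)CC3)CC2)c(C)c1` is one of three compounds measured in a functional assay on DLD-1 cells (Homo sapiens) for antiproliferative activity, read by CellTiter-Glo, with a stated time of 72 h (on this read-out higher numbers stand for weaker inhibition and lower numbers for stronger inhibition), where compound 1 gives 19 nM. That number is the second highest of the three. Compound 2 `COc1ccc(OC)c(S(=O)(=O)N2CCC(N3CCC(C)CC3)CC2)c1` gives 4.5 nM in this assay, a lower number that lies beyond the scatter. Compound 3 `CC1CCN(C2CCN(S(=O)(=O)c3ccccc3-c3ccc(Cl)cc3)CC2)CC1` gives 202 nM in this assay, a higher number that also lies beyond the scatter. Compound 4 `Cc1cc(C)c(S(=O)(=O)N2CCC(c3ccccc3)CC2)c(C)c1` has not yet been measured in this assay; it differs from compound 1 in one place: phenyl in place of 4-(2-hydroxyethyl)piperidin-1-yl on a saturated ring carbon. Among the compounds with values here, no measured pair shows this change, so the expected step is a 21-fold higher number from compound 1 to compound 4 (1.32 log units; beyond the scatter), a rise in the number beyond the scatter. Compound 4 is estimated at 400 nM in this assay, with a range from 50 nM to 4000 nM.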

Compound 4, half-maximal inhibitory concentration: > 5000 nM
Compound 4 ended at the assay's limit; the forecaster's own chance of this, stated with the estimate: 15%; middle value at least 12-fold (1.09 log units) from the limit.
By their numbers in this assay, from the lowest: compound 2; then compound 1; then compound 3. At a limit, above all of these: compound 4.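

Compound 4 gives > 5000 nM in this assay, which is a limit of the assay and not a number. Going by these compounds alone, on this saturated ring carbon, phenyl in place of 4-(2-hydroxyethyl)piperidin-1-yl gives an at least 260-fold higher number from compound 1 to compound 4 (2.42 log units; beyond the scatter), so the position does not accept every six-membered ring, whereas the earlier compounds all carry a piperidin-1-yl group there. The step is bounded by that limit: the limit of > 5000 nM in this assay, at which 1 of the 4 values shown sits.

The change replaces the nitrogen, the saturated ring and the 2-hydroxyethyl chain at once, and the compounds shown cannot separate these. As far as these compounds go, whether a cyclohexyl group or an unsubstituted piperidin-1-yl group on this carbon would keep the number low stays open.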